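This account rests on a few compounds, and the source may have more. Where it says the series, first, only, none or still open, it means among the compounds named here.

Compound 3 `O=C(CNC(=O)c1nn(-c2ccccc2)c(=O)c2ccccc12)Nc1nc2ccc(Cl)cc2s1` shows the lowest number of the three in an assay on L cells for inhibition of Protein-serine O-palmitoleoyltransferase porcupine (Mus musculus), read by reporter gene assay, with a stated time of 24 h; on this read-out higher numbers stand for an effect only at larger amounts of compound and lower numbers for an effect already at smaller amounts: compound 3 gives 30 nM. Compound 1 `O=C(CNC(=O)c1nn(-c2ccccc2)c(=O)c2ccccc12)Nc1nc2ccc(F)cc2s1` gives 470 nM, and compound 2 `O=C(CNC(=O)c1nn(-c2ccccc2)c(=O)c2ccccc12)Nc1nc2ccccc2s1` gives 2600 nM. Compound 4 `O=C(CNC(=O)c1nn(-c2ccccc2)c(=O)c2ccccc12)Nc1nc2ccc([N+](=O)[O-])cc2s1` differs from compound 3 in one place: nitro in place of chloro on an aromatic carbon. Among the compounds with values here, no measured step exchanges chloro for nitro. Within the data shown here, the steps that bear on this change sit at the same aromatic carbon: an 87-fold lower number from compound 2 to compound 3 (1.94 log units; beyond the scatter) and a 16-fold lower number from compound 1 to compound 3 (1.19 log units; beyond the scatter), both large, so what sits at that carbon strongly governs the number in this assay. Since nitro is neither hydrogen nor chloro, a step beyond the scatter in either direction is possible, and a moderate rise is expected. Compound 4 is therefore estimated at 100 nM, ranging from 20 nM to 600 nM, which means a 3.3-fold higher number from compound 3 to compound 4 (0.52 log units; beyond the scatter).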

Compound 4, half-maximal effective concentration: 240 nM
For compound 4 the middle estimate is 2.4-fold (0.38 log units) below the measured one; low and high end bracket the measured number.
By their numbers in this assay, from the lowest: compound 3; then compounds 4 and 1 (each within the scatter of the next); then compound 2.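

With nitro at this aromatic carbon, this assay gives an 11-fold lower number from compound 2 to compound 4 (1.03 log units; beyond the scatter), so the gain over hydrogen is not confined to the halogens among these compounds. Nitro does not match chloro, however, with an 8.0-fold higher number from compound 3 to compound 4 (0.90 log units; beyond the scatter), while against fluoro it gives a 2.0-fold lower number from compound 1 to compound 4 (0.29 log units; within the scatter), so those two groups cannot be told apart here. Chloro thus stands clear of all three other groups at this carbon.

Nothing at hand explains why chloro stands apart from nitro and fluoro. Going by these compounds, whether an amine, a methyl or a bromo at this carbon would fall nearer chloro or nearer hydrogen remains open.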